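This account rests on a few compounds, and the source may have more. Where it says the series, first, only, none or still open, it means among the compounds named here.

Measured compounds in an ADME assay on L929 cells (Mus musculus) for cytotoxicity, read by resazurin assay, with a stated time of 72 h; on this read-out higher numbers stand for weaker inhibition and lower numbers for stronger inhibition:

Compound 1 `COCOc1cccc(C(=O)/C=C/c2ccc3c(c2)B(O)OC3)c1` — > 10 ug/mL
Compound 2 `Cc1cccc(C(=O)/C=C/c2ccc3c(c2)B(O)OC3)c1` — 8.56 ug/mL
Compound 3 `O=C(/C=C/c1ccc2c(c1)B(O)OC2)c1ccc(Br)cc1` — > 10 ug/mL

All three compounds share one core and differ only in the aryl group attached to the carbonyl carbon. For compound 1 the value in this assay is a limit of the assay, > 10 ug/mL, and not a number. In this assay compound 2 gives 8.56 ug/mL. For compound 3 the value is again a limit of the assay, > 10 ug/mL, so compound 3 stands at the ceiling of what this assay reports, together with compound 1 (the limit of > 10 ug/mL in this assay, at which 2 of the 3 values shown sit).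

Compound 4 `O=C(/C=C/c1ccc2c(c1)B(O)OC2)c1cccc(O)c1` has not yet been measured. It differs from compound 3 in one place: 3-hydroxyphenyl in place of 4-bromophenyl on a carbonyl carbon.

Within the data shown here, two measured steps bear on this change. The step of an at least 1.1-fold lower number from compound 1 to compound 2 (0.06 log units; that floor lies within the scatter) and the step of an at least 1.1-fold higher number from compound 2 to compound 3 (0.06 log units; that floor lies within the scatter) both alter the aryl group on the carbonyl carbon, and each is only a floor lying within the scatter. Among the measured compounds shown here, nothing measured so far shows a change in this position moving the number beyond the scatter. The expectation for the step that the limit leaves unreadable from compound 3 to compound 4 is therefore no shift beyond the scatter, and compound 4 is estimated at 12 ug/mL, with a range from 5 ug/mL to 30 ug/mL, most likely reported again as a limit.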

Compound 4, half-maximal inhibitory concentration: 7.56 ug/mL
The estimate for compound 4 lay 1.6-fold (0.20 log units) above the measured number, and the stated range covers the measured number.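

The aryl group on the carbonyl carbon now has its first comparison in this assay with a real number on both sides, and it reads a 1.1-fold lower number from compound 2 to compound 4 (0.05 log units; within the scatter). This means that hydroxy in place of methyl on an aromatic carbon, a change of a single small group on the ring, leaves the number within the normal spread of repeated measurements. The other two comparisons give only minimum sizes, an at least 1.3-fold lower number from compound 3 to compound 4 (0.12 log units; that floor lies within the scatter) and an at least 1.3-fold lower number from compound 1 to compound 4 (0.12 log units; that floor lies within the scatter), because each of them starts from a compound that sits at the limit of the assay: the limit of > 10 ug/mL in this assay, at which 2 of the 4 values shown sit.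

As far as these compounds go, the true distance of compound 1 and of compound 3 from compound 4 therefore stays unknown, so the move from 4-bromophenyl, with 0 hydrogen-bond donors, to 3-hydroxyphenyl, with 1, could be small or could be larger than its floor. The compounds shown also leave open whether an amine or a carboxylic acid on this aromatic ring, or a longer chain in place of the hydroxy, would move the number beyond the scatter.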